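The compounds below may be only part of what the source reports. "The series", "measured", "known", "first", "only" and "open" are said of these compounds alone.

Working notes on the series.

Compound 1 `O=C1c2cccc([N+](=O)[O-])c2NC[C@@]12[C@H](c1ccc(F)cc1)[C@@H](c1ccccc1)N[C@]21C(=O)Nc2ccc(Br)cc21` and compound 2 `O=C1c2cccc([N+](=O)[O-])c2NC[C@@]12[C@H](c1ccc(Br)cc1)[C@@H](c1ccccc1)N[C@]21C(=O)Nc2ccc(F)cc21` differ only in which of the two halogens sits on which ring. In a functional assay on HeLa cells (Homo sapiens) for cytotoxicity, read by MTT assay, with a stated time of 72 h (on this read-out higher numbers stand for weaker inhibition and lower numbers for stronger inhibition), compound 1 gives 26000 nM, and in this assay compound 2 gives 26000 nM, so compound 2 stands level with compound 1 at the digits recorded, within the scatter. Going by the values given here, no step between the two is therefore treated as a change.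

Compound 3 `O=C1c2cccc([N+](=O)[O-])c2NC[C@@]12[C@H](c1ccc(F)cc1)[C@@H](c1ccccc1)N[C@]21C(=O)Nc2ccc(F)cc21` is the next member to be run in this assay. It differs from compound 2 by fluoro in place of bromo on an aromatic carbon. Both measured compounds carry one fluoro and one bromo, and swapping their places left the value unchanged, so a shared fluoro at both sites is expected to give no step beyond the scatter, with no change at the digits printed from compound 2 to compound 3 (within the scatter) as the estimated step. Compound 3 is estimated at 26000 nM, ranging from 12000 nM to 55000 nM.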

Compound 3, half-maximal inhibitory concentration: 20000 nM
Beside the measured number, compound 3's estimate is 1.3-fold (0.11 log units) above it; measured number inside the range.
By their numbers in this assay, from the lowest: compounds 3, 1 and 2 (each within the scatter of the next).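

In this assay the replacement of bromo by fluoro as 4-bromophenyl to 4-fluorophenyl gives a 1.3-fold lower number from compound 2 to compound 3 (0.11 log units; within the scatter) and the same replacement on the other halogen-bearing ring gives a 1.3-fold lower number from compound 1 to compound 3 (0.11 log units; within the scatter) with the rest of the structure unchanged. Going by these compounds alone, each halogen site is thus read on its own for the first time, something the earlier pair could not offer since its members differ in two places, and at neither site does the choice of fluoro or bromo register beyond the scatter. No measurement in hand accounts for this result.

The compounds shown leave open whether anything other than a halogen at these two sites, such as an amine, a methoxy group or a carboxylic acid, would shift the number. They also leave open what a hydrogen at either site would give, and how the nitro group and the unsubstituted phenyl contribute.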